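Methyl to methoxy on the pendant aryl ring

The source may report more compounds than this note shows. Statements on the series, on what has been measured and on what is new or still open speak of the compounds shown alone.

Of the compounds shown here, three of one series have been measured in a functional assay on HeLa cells (Homo sapiens) for antiproliferative activity, read by MTT assay, with a stated time of 48 h, in the presence of a further agent that is not named here; a higher number here means a weaker inhibitor of growth, a lower number a stronger inhibitor of growth. Compound 1 `O=C(NOCc1ccccc1)c1cn(-c2ccccc2)nc1-c1ccccc1` gives 8830 nM. Compound 2 `Cc1ccc(-c2nn(-c3ccccc3)cc2C(=O)NOCc2ccccc2)cc1` gives 6690 nM, and compound 3 `Cc1ccc(-c2nn(-c3ccccc3)cc2C(=O)NOCc2ccc(Cl)cc2Cl)cc1` gives 2040 nM. Among these three numbers compound 2 stands second highest: its nearest neighbour is compound 1, and the step of a 1.3-fold lower number from compound 1 to compound 2 (0.12 log units; within the scatter) lies within the scatter, while its furthest neighbour is compound 3, reached by the step of a 3.3-fold lower number from compound 2 to compound 3 (0.52 log units; beyond the scatter), which goes beyond the scatter.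

Compound 4 `COc1ccc(-c2nn(-c3ccccc3)cc2C(=O)NOCc2ccccc2)cc1` has not yet been measured in this assay. It differs from compound 2 by methoxy in place of methyl on an aromatic carbon. Among the measured compounds shown here, only one measured step touches the same aromatic carbon, namely a 1.3-fold lower number from compound 1 to compound 2 (0.12 log units; within the scatter), and that step stayed within the scatter. The other measured step, a 3.3-fold lower number from compound 2 to compound 3 (0.52 log units; beyond the scatter), alters a different part of the molecule and so says little about this position. On this evidence no step beyond the scatter is expected from the exchange of methyl for methoxy, in either direction.

Compound 4 is therefore estimated to give about 6500 nM in this assay, with a range from 2500 nM to 17000 nM. This estimate corresponds to an expected step of a 1.0-fold lower number from compound 2 to compound 4 (0.01 log units; within the scatter), which is expected to remain within the scatter.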

Compound 4, concentration for 50% growth inhibition: 2640 nM
Compound 4: middle estimate off by 2.5-fold (0.39 log units), on the high side, within the range that was stated.
By their numbers in this assay, from the lowest: compounds 3 and 4 (each within the scatter of the next); then compounds 2 and 1 (each within the scatter of the next).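

The 4-methylphenyl to 4-methoxyphenyl exchange in this assay gives a 2.5-fold lower number from compound 2 to compound 4 (0.40 log units; beyond the scatter), showing that this aromatic carbon, para to a large group, can respond to substitution, which a 1.3-fold lower number from compound 1 to compound 2 (0.12 log units; within the scatter) had not shown. Measured against hydrogen at the same carbon, methoxy gives a 3.3-fold lower number from compound 1 to compound 4 (0.52 log units; beyond the scatter), so here the step from hydrogen goes beyond the scatter with methoxy but not with methyl, and the identity of the group matters more than the mere presence of a substituent. Nothing available here accounts for the difference between methoxy and methyl at this position.

The compounds shown leave open whether a hydroxyl group, an ethoxy group or an amine at this same carbon would give a number like that of compound 4 or one nearer that of compound 2, and so whether the oxygen of methoxy is what counts. They also leave open whether 4-methoxyphenyl and the 2,4-dichlorophenyl group, which gave a 3.3-fold lower number from compound 2 to compound 3 (0.52 log units; beyond the scatter), would add up when carried together in one molecule.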